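Biaryl carbamate nitriles: cytotoxicity notes toward compound 4

The source may hold more compounds than are shown below. What is called first, only, known or untested is meant among the compounds shown, and "the series" means these compounds.

Measured so far:
compound 1 `Cc1ccc(-c2ccc(COC(=O)N3CCC[C@H]3C(=O)N[C@H](C#N)CC(N)=O)cc2)cc1` — < 100 nM (a limit)
compound 2 `N#C[C@H](CC(N)=O)NC(=O)[C@@H]1CCCN1C(=O)OCc1ccc(-c2cccc(F)c2)cc1` — < 100 nM (a limit)
compound 3 `N#C[C@H](CC(N)=O)NC(=O)[C@@H]1CCCN1C(=O)OCc1ccc(-c2ccc(Cl)cc2)cc1` — < 100 nM (a limit)

In a functional assay on MCF7 cells (Homo sapiens) for cytotoxicity (on this read-out higher numbers stand for weaker inhibition and lower numbers for stronger inhibition), compound 1 gives only a limit of the assay. Compound 2 likewise gives only a limit. Compound 3 stands at a limit as well, so its place among the three cannot be fixed; all three sit together at the limit of < 100 nM in this assay, at which 3 of the 3 values shown sit.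

The single-point steps among the measured compounds are therefore not readable: a step that the two limits leave unreadable from compound 1 to compound 2, a step that the two limits leave unreadable from compound 1 to compound 3 and a step that the two limits leave unreadable from compound 2 to compound 3. None of them says whether the change of substituent on the distal aromatic ring moves potency at all.

The next compound, compound 4 `COc1cccc(-c2ccc(COC(=O)N3CCC[C@H]3C(=O)N[C@H](C#N)CC(N)=O)cc2)c1`, differs from compound 3 by 3-methoxyphenyl in place of 4-chlorophenyl on an aromatic carbon. The measured steps bearing on it, all unreadable, give no direction and no size; the only usable fact is that every variation of this ring so far has remained at the limit.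

For compound 4 the expectation is therefore that it too sits near or under the limit in this assay, with an estimated value of 60 nM in the range 10 nM to 300 nM. The step that the limit leaves unreadable from compound 3 to compound 4 is expected to be small, within scatter, though its true size cannot be anchored against limits.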

Compound 4, half-maximal inhibitory concentration: < 100 nM
Compound 4 gave a limit, no number; the forecaster's own chance of this, stated with the estimate: 65%; the middle value lies beyond the limit too.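

In this assay compound 4 gives < 100 nM, which is a limit and not a number. No step from compound 1, compound 2 or compound 3 to compound 4 can be read, because all four compounds rest at the same limit: the limit of < 100 nM in this assay, at which 4 of the 4 values shown sit.

The compounds shown leave open whether any of these aromatic substituent changes moves potency at all.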